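Trading a methylamide for a carboxylic acid

The compounds below may be only part of what the source reports. "The series", "measured", "known", "first", "only" and "open" are said of these compounds alone.

Of the compounds shown here, three sharing one core have been tested in an assay on BaF3 cells for inhibition of thrombopoietin receptor (Homo sapiens); a lower number here means that less compound is needed, a higher number that more compound is needed for the effect. Compound 1 `CC1=NN(c2ccc3c(c2)CCC3)C(=O)/C1=C(/C)NNC(=S)N1CCc2cc(C(=O)O)ccc21` carries a carboxy group and in this assay gives 3 nM. Compound 2 `CC1=NN(c2ccc(C)c(C)c2)C(=O)/C1=C(/C)NNC(=S)N1CCc2cc(C(=O)N3CCOCC3)ccc21` carries a morpholine amide and gives 31 nM. Compound 3 `CNC(=O)c1ccc2c(c1)CCN2C(=S)NN/C(C)=C1\C(=O)N(c2ccc(C)c(C)c2)N=C1C` carries a methylamide and gives 22 nM. Among these three numbers compound 3 holds the second highest; its value sits within the scatter of that of compound 2, while compound 1 lies a clear distance lower.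

Compound 4 `CC1=NN(c2ccc(C)c(C)c2)C(=O)/C1=C(/C)NNC(=S)N1CCc2cc(C(=O)O)ccc21` has not yet been measured. It differs from compound 3 by hydroxy in place of methylamino on a carbonyl carbon. Among the compounds with values here, the one measured step that touches this part of the molecule, a 1.4-fold lower number from compound 2 to compound 3 (0.15 log units; within the scatter), exchanged one amide for another and stayed within the scatter. Within the data shown here, no measured step exchanges an amide for a carboxy group on the same aryl partner, so the direction rests on the values alone. Among the measured compounds shown here, the carboxy group is present only in compound 1, and that compound gives a number well below the one for compound 3. For compound 4 a move to a lower number is therefore expected, a 2.2-fold lower number from compound 3 to compound 4 (0.34 log units; beyond the scatter), though its size is uncertain. Compound 4 is estimated to give 10 nM, with a range from 3 nM to 35 nM.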

Compound 4, half-maximal effective concentration: 6 nM
The estimate for compound 4 lay 1.7-fold (0.22 log units) above the measured number, and the stated range covers the measured number.
By their numbers in this assay, from the lowest: compounds 1 and 4 (each within the scatter of the next); then compounds 3 and 2 (each within the scatter of the next).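

On the same 3,4-dimethylphenyl partner, hydroxy in place of methylamino on a carbonyl carbon gives a 3.7-fold lower number from compound 3 to compound 4 (0.56 log units; beyond the scatter) in this assay and hydroxy in place of morpholin-4-yl gives a 5.2-fold lower number from compound 2 to compound 4 (0.71 log units; beyond the scatter), whereas exchanging one amide for the other gave only a 1.4-fold lower number from compound 2 to compound 3 (0.15 log units; within the scatter). Within the data shown here, this is the first direct comparison showing that, at this position, moving from either amide to the carboxy group matters more than the choice between these two amides; until now, the low number of compound 1 could equally have belonged to its different aryl partner. With the carboxy group held in place, 3,4-dimethylphenyl in place of 2,3-dihydro-1H-inden-5-yl gives a 2.0-fold higher number from compound 1 to compound 4 (0.30 log units; within the scatter), so the two aryl partners cannot be told apart in these data.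

The compounds shown offer no measurement that explains the link between the carboxy group and the lower number. As far as these compounds go, it also remains open whether a tetrazole ring, a sulfonamide or a longer chain ending in a carboxylic acid would keep that lower number at this place.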